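From chloro to trifluoromethyl on a shared core

This account rests on a few compounds, and the source may have more. Where it says the series, first, only, none or still open, it means among the compounds named here.

Compound 1 `CC[C@@H](Nc1c(C#N)c(-c2ccc(-c3cccc(C)c3F)cc2)nc2cnccc12)C(N)=O` gives 3
Compound 2 `CC[C@@H](Nc1c(C#N)c(-c2ccc(-c3ccccc3Cl)cc2)nc2cnccc12)C(N)=O` gives 2.9
Compound 3 `CC[C@@H](Nc1c(C#N)c(-c2ccc(-c3ccccc3C(F)(F)F)cc2)nc2cnccc12)C(N)=O` has not yet been measured

All of these numbers come from a physicochemical assay for lipophilicity, read by HPLC, at pH 7.5 (on this read-out lower numbers stand for lower lipophilicity and higher numbers for higher lipophilicity), and only two are known so far. Compound 2 gives 2.9 and stands level, within the scatter, with compound 1 at 3 on this short scale. Among the compounds with values here, the one measured step is a number 0.10 log units lower from compound 1 to compound 2 (within the scatter) and it came with 2-chlorophenyl in place of 2-fluoro-3-methylphenyl on an aromatic carbon.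

Compound 3 departs from compound 2 by trifluoromethyl in place of chloro on an aromatic carbon with trifluoromethyl in place of chloro on an aromatic carbon, ortho to a large group. Within the data shown here, no measured step contains trifluoromethyl, so the step to compound 2 bears on this change only loosely. It shows that one exchange at this place moved the number very little. A small upward step in this assay seems the likeliest outcome, as the entering group is the larger one. The expected step is a number 0.20 log units higher from compound 2 to compound 3 (within the scatter) and it may well not clear the scatter. For compound 3 the estimate is 3.1 with a range of 2.8 to 3.5 expected.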

Compound 3, distribution coefficient: 3.1
Estimate against measurement, compound 3: no gap at the digits printed; the range from low to high includes it.
By their numbers in this assay, from the lowest: compounds 2, 1 and 3 (each within the scatter of the next).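

Compound 3 extends what was seen at this position to a third substituent and to a larger exchange: where chloro leaves and trifluoromethyl enters, 1 heavy atom gives way to 4, and in this assay the result is a number 0.20 log units higher from compound 2 to compound 3 (within the scatter) at this place ortho to a large group. The exchange of the whole ring substituent gives the same kind of reading, a number 0.10 log units higher from compound 1 to compound 3 (within the scatter) and, with the earlier step between compound 1 and compound 2, every printed step among the three compounds lies within the scatter, so the read-out separates none of these three substituted phenyl groups from another. No independent evidence accompanies these numbers to account for how closely they agree.

All the groups compared at this place lack the hydrogen-bond donors and acceptors counted for chloro and trifluoromethyl, so the compounds shown leave open whether an amine or a carboxylic acid in the same position would give a step beyond the scatter. They also leave open whether a longer chain there, or the same exchange of chloro for trifluoromethyl elsewhere on the shared core, would read as closely in this assay as the steps seen here.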